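The source may hold more compounds than are shown below. What is called first, only, known or untested is meant among the compounds shown, and "the series" means these compounds.

Measured so far in a functional assay on Jurkat cells (Homo sapiens); on this read-out higher numbers stand for weaker inhibition and lower numbers for stronger inhibition:
- compound 1 `C[C@H](NC(=O)C(=O)NCc1ccc(Cl)cc1)C(=O)N[C@@H](CC(=O)O)C(=O)COc1c(F)c(F)cc(F)c1F`: 8.4 nM
- compound 2 `Cc1ccc(C)c(CNC(=O)C(=O)N[C@@H](C)C(=O)N[C@@H](CC(=O)O)C(=O)COc2c(F)c(F)cc(F)c2F)c1`: 11 nM

Among the compounds with values here, compound 2 stands at 11 nM, within the scatter of the only other number available. Compound 3 `C[C@H](NC(=O)C(=O)NCc1cc(F)cc(F)c1)C(=O)N[C@@H](CC(=O)O)C(=O)COc1c(F)c(F)cc(F)c1F` differs from it as follows: 3,5-difluorophenyl in place of 2,5-dimethylphenyl on a saturated chain carbon bound to an amide-type nitrogen. The 3,5-difluorophenyl group takes the place of the 2,5-dimethylphenyl group. Within the data shown here, the one measured step at this place is a 1.3-fold higher number from compound 1 to compound 2 (0.12 log units; within the scatter), and it stayed within the scatter. A single step is thin evidence, but no change beyond the scatter is expected in this assay. The expected step is a 1.1-fold lower number from compound 2 to compound 3 (0.04 log units; within the scatter). The estimate for compound 3 is 10 nM, with an expected range of 4 nM to 25 nM.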

Compound 3, half-maximal inhibitory concentration: 16 nM
Compound 3: the middle estimate sits 1.6-fold (0.20 log units) below what was measured, within the range that was stated.
By their numbers in this assay, from the lowest: compounds 1, 2 and 3 (each within the scatter of the next).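

In this assay, the 3,5-difluorophenyl group gives a 1.5-fold higher number from compound 2 to compound 3 (0.16 log units; within the scatter) and a 1.9-fold higher number from compound 1 to compound 3 (0.28 log units; within the scatter). Three differently substituted phenyl groups, carrying fluorine, chlorine or methyl, therefore read alike at this place on a saturated chain carbon bound to an amide-type nitrogen, so this change has shown no effect beyond the scatter. Nothing available explains this result. The compounds shown leave open whether the same holds for a phenyl ring bearing an amine or a carboxylic acid. A cyclohexyl group in place of the phenyl ring also remains an open case.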